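Compound 2 to compound 3: changing the acid chain

The source may report more compounds than this note shows. Statements on the series, on what has been measured and on what is new or still open speak of the compounds shown alone.

Measured in an ADME assay on the whole organism (strain CD-1) for pharmacokinetics, with Mus musculus as the target, at a dose of 3 mg/kg by the intravenous route; a higher number here means more compound in the circulation at the dose given, a lower number less compound in the circulation:
- compound 1 `CN(Cc1ccccc1OCCC[C@@H]1C[C@H]1C(=O)O)C(=O)c1ccc(-c2ccco2)cc1` gives 40500 ng.h/mL
- compound 2 `C/C(=C\C(=O)O)CCCOc1ccccc1CN(C)C(=O)c1ccc(-c2ccco2)cc1` gives 4700 ng.h/mL

Compound 2 holds the lower of the two numbers. Compound 3 `CC(CCOc1ccccc1CN(C)C(=O)c1ccc(-c2ccco2)cc1)CCC(=O)O` has yet to be measured and differs from compound 2 thus: 3-carboxy-1-methylpropyl in place of 3-carboxy-2-methylprop-2-en-1-yl on a saturated chain carbon, two bonds along the chain from an oxygen on an aromatic ring. In short, 3-carboxy-1-methylpropyl takes the place of 3-carboxy-2-methylprop-2-en-1-yl on a saturated chain carbon, two bonds along the chain from an oxygen on an aromatic ring. For the measured compounds named here, only one measured step bears on this, and only loosely: an 8.6-fold lower number from compound 1 to compound 2 (0.94 log units; beyond the scatter). That step shows the chain can matter in this assay, but it is a different change, and no measurement covers the present one. No step beyond the scatter is therefore expected. The expected outcome is a 1.2-fold higher number from compound 2 to compound 3 (0.07 log units; within the scatter). For compound 3 the estimated value is 5500 ng.h/mL, within an expected range of 1800 ng.h/mL to 17000 ng.h/mL.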

Compound 3, area under the concentration-time curve: 11800 ng.h/mL
Estimate against measurement, compound 3: 2.1-fold (0.33 log units) below; low and high end bracket the measured number.
By their numbers in this assay, from the lowest: compound 2; then compound 3; then compound 1.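

In this assay, 3-carboxy-1-methylpropyl in place of 3-carboxy-2-methylprop-2-en-1-yl gave a step beyond the scatter (a 2.5-fold higher number from compound 2 to compound 3 (0.40 log units; beyond the scatter)), so this position responds to a change that keeps the same heavy atoms and goes from 2 double bonds outside aromatic rings to 1. The saturated chain still did not match the (2-carboxycyclopropyl)methyl group of compound 1 (a 3.4-fold lower number from compound 1 to compound 3 (0.54 log units; beyond the scatter)), which leaves compound 1 with the highest number of the three. No measurement shown explains either step. The compounds shown cannot separate the loss of the double bond from the shift of the methyl group, since the two change together between compound 2 and compound 3. Also open, from the compounds shown here alone, is how an unbranched chain, a longer chain or a tetrazole in place of the carboxylic acid would behave at this position.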